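This account rests on a few compounds, and the source may have more. Where it says the series, first, only, none or still open, it means among the compounds named here.

Measured compounds in a functional assay on HeLa cells (Homo sapiens) for inhibition, read by MTT assay, with a stated time of 72 h; on this read-out lower numbers stand for stronger inhibition and higher numbers for weaker inhibition:
compound 1, `Brc1ccc(-c2nnc(SCCCN3CCN(c4nc5ccccc5o4)CC3)o2)cc1`, gives 187000 nM
compound 2, `CC(C)(C)Oc1ccc(-c2nnc(SCCCN3CCN(c4nc5ccccc5o4)CC3)o2)cc1`, gives 269000 nM
compound 3, `Brc1ccc(-c2nnc(SCCCN3CCN(c4nc5ccccc5s4)CC3)o2)cc1`, gives 243000 nM

Compound 4, `CC(C)(C)Oc1ccc(-c2nnc(SCCCN3CCN(c4nc5ccccc5s4)CC3)o2)cc1`, has not yet been measured in this assay. It differs from compound 3 by tert-butoxy in place of bromo on an aromatic carbon. The same change has been made once before in this set, from compound 1 to compound 2, where it gave a 1.4-fold higher number from compound 1 to compound 2 (0.16 log units; within the scatter). The two places read the same word for word, so this is the same change carried onto a second core. The cores of compound 1 and compound 3 differ by 1,3-benzothiazol-2-yl in place of 1,3-benzoxazol-2-yl on an amine nitrogen in a ring, a change that gave a 1.3-fold higher number from compound 1 to compound 3 (0.11 log units; within the scatter). All three measured numbers lie within the scatter of one another, so no order among them can be stated, and compound 2 and compound 3 in particular stand very close. Within the data shown here, the step from compound 3 to compound 4 is expected to be a 1.4-fold higher number from compound 3 to compound 4 (0.15 log units; within the scatter), resting on the single earlier instance a 1.4-fold higher number from compound 1 to compound 2 (0.16 log units; within the scatter); with one precedent and all values within scatter, the expectation is of little or no movement. Compound 4 is therefore estimated at 340000 nM, with a range from 170000 nM to 680000 nM.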

Compound 4, half-maximal inhibitory concentration: 217000 nM
For compound 4 the middle estimate is 1.6-fold (0.20 log units) above the measured one, within the range that was stated.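

In this assay, tert-butoxy in place of bromo on the core of compound 3 gives a 1.1-fold lower number from compound 3 to compound 4 (0.05 log units; within the scatter) and agrees with its earlier instance on the core of compound 1: the same change on two cores in this assay, a 1.4-fold higher number (0.16 log units; within the scatter) from compound 1 to compound 2 and a 1.1-fold lower number (0.05 log units; within the scatter) from compound 3 to compound 4, 1.6-fold (0.21 log units) apart, within the scatter of two such steps.
The change from 1,3-benzoxazol-2-yl to 1,3-benzothiazol-2-yl, read on the tert-butoxy pair, gives a 1.2-fold lower number from compound 2 to compound 4 (0.09 log units; within the scatter) and likewise agrees with its earlier instance: the same change on two cores in this assay, a 1.3-fold higher number (0.11 log units; within the scatter) from compound 1 to compound 3 and a 1.2-fold lower number (0.09 log units; within the scatter) from compound 2 to compound 4, 1.6-fold (0.21 log units) apart, within the scatter of two such steps.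
Among these compounds, each change therefore carries from one core to the other in the limited sense that no step in either pair leaves the scatter, but this shows neither a direction nor a real size for either change, and two small steps per change cannot separate a transferable effect from no effect.

Still open, from the compounds shown here alone, is whether a group such as an amine or a carboxylic acid in place of bromo or tert-butoxy on the phenyl ring would give a step beyond the scatter. Also open, going by these compounds, is whether a longer chain in the linker would do so, and whether any such step would carry between the two cores.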